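Halogen swap on the fused ring of the shared core

The source may report more compounds than this note shows. Statements on the series, on what has been measured and on what is new or still open speak of the compounds shown alone.

Compound 1 `COc1cc(Sc2c[nH]c3ccccc23)cc(OC)c1OC` gives 34 nM in a functional assay on MCF7 cells (Homo sapiens) for inhibition, with a stated time of 48 h; a lower number here means a stronger inhibitor, a higher number a weaker inhibitor. For the measured compounds named here, compound 2 `COc1cc(Sc2c[nH]c3ccc(Cl)cc23)cc(OC)c1OC` gives 77 nM in this assay, the highest of the two numbers measured so far; its only neighbour is compound 1, and the step of a 2.3-fold higher number from compound 1 to compound 2 (0.36 log units; beyond the scatter) is modest. Compound 3 `COc1cc(Sc2c[nH]c3ccc(Br)cc23)cc(OC)c1OC` is unmeasured; it differs from compound 2 by bromo in place of chloro on an aromatic carbon. Going by the values given here, no measured step exchanges one halogen for another, so the only step that bears on this change is a 2.3-fold higher number from compound 1 to compound 2 (0.36 log units; beyond the scatter), which shows what adding a halogen at this place did. A bromo for chloro exchange is a smaller change than hydrogen to chloro, so in this assay no step beyond the scatter is expected, with a slight lean toward a higher number. Compound 3 is expected to give 90 nM in this assay, between 40 nM and 200 nM. The expected step is a 1.2-fold higher number from compound 2 to compound 3 (0.07 log units; within the scatter), inside the scatter.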

Compound 3, half-maximal inhibitory concentration: 43 nM
For compound 3 the middle estimate is 2.1-fold (0.32 log units) above the measured one; measured number inside the range.
By their numbers in this assay, from the lowest: compounds 1, 3 and 2 (each within the scatter of the next, the first and the last beyond it).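

In this assay, exchanging chloro for bromo is a 1.8-fold lower number from compound 2 to compound 3 (0.25 log units; within the scatter), and replacing the hydrogen on this aromatic carbon with bromo is a 1.3-fold higher number from compound 1 to compound 3 (0.10 log units; within the scatter). A halogen at this place therefore does not always produce a step beyond the scatter: among the steps shown, only a 2.3-fold higher number from compound 1 to compound 2 (0.36 log units; beyond the scatter) does so, and compound 3 goes against any reading that halogens as a class shift the number at this position. Nothing shown accounts for the difference between the chloro and bromo steps.

The compounds shown leave open how this aromatic carbon would respond to a group other than a halogen, such as an amine or a carboxylic acid. They also leave open whether fluoro or iodo would stay within the scatter of compound 1.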